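Replacing a Cyanophenyl with a Diisopropylamino Chain

The source may hold more compounds than are shown below. What is called first, only, known or untested is meant among the compounds shown, and "the series" means these compounds.

Compound 3 `N#Cc1cccc(Cn2ccc3nc(-c4ccccc4)nc-3c2)c1` carries a 3-cyanophenyl group on the shared core. In an ADME assay on MDBK cells (Bos taurus) for cytotoxicity (on this read-out higher numbers stand for lower toxicity in this test and lower numbers for higher toxicity in this test), compound 3 gives only a limit of the assay, > 100000 nM. Compound 1 `COc1ccc(Cn2ccc3nc(-c4ccccc4)nc-3c2)cc1` likewise gives a limit, > 100000 nM. Compound 2 `Clc1ccccc1Cn1ccc2nc(-c3ccccc3)nc-2c1` also gives a limit, > 100000 nM. Because (the limit of > 100000 nM in this assay, at which 3 of the 3 values shown sit), none of the steps among these three can be read: a step that the two limits leave unreadable from compound 1 to compound 2, a step that the two limits leave unreadable from compound 1 to compound 3 and a step that the two limits leave unreadable from compound 2 to compound 3 all stay without a size. Compound 4 `CC(C)N(CCn1ccc2nc(-c3ccccc3)nc-2c1)C(C)C` is the unmeasured compound, and it differs from compound 3 as follows: (diisopropylamino)methyl in place of 3-cyanophenyl on a saturated chain carbon bound to an aromatic nitrogen. With no readable step to lean on, the step expected here, a number no higher from compound 3 to compound 4 (the limit leaves the size open), is taken as none beyond the scatter. Compound 4 is therefore estimated at 100000 nM, with a range from 30000 nM to 300000 nM.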

Compound 4, half-maximal cytotoxic concentration: > 100000 nM
Compound 4 ended at the assay's limit (the forecaster's own chance of this, stated with the estimate: 70%); the middle value lies on the limit itself.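

The steps from compound 1, compound 2 and compound 3 to compound 4 cannot be read, as all four compounds give only a limit: the limit of > 100000 nM in this assay, at which 4 of the 4 values shown sit. In this assay the compounds shown leave open what change on the shared core, if any, would bring a value within the assay's range.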